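Shifting the Methoxyphenyl Ring on an Inactive Core

The source may report more compounds than this note shows. Statements on the series, on what has been measured and on what is new or still open speak of the compounds shown alone.

Compound 1 `COc1ccc(N2C(=O)COc3ccc(-c4cnc5ccccc5c4)cc32)cc1` was tested in a functional assay on A549 cells (Homo sapiens) for antiproliferative activity, read by MTT assay, with a stated time of 72 h; on this read-out higher numbers stand for weaker inhibition and lower numbers for stronger inhibition. In this assay compound 1 gives > 40000 nM, which is a limit of the assay rather than a measured number. Compound 2 `COc1ccc(N2C(=O)COc3ccc(-c4cnc(OC)c(NS(=O)(=O)c5ccc(F)cc5)c4)cc32)cc1` gives 1350 nM in this assay. Compound 3 `O=C1COc2ccc(-c3ccc(O)cc3)cc2N1` gives > 40000 nM in this assay, again a limit. Compound 4 `COc1cccc(N2C(=O)COc3ccc(-c4cnc5ccccc5c4)cc32)c1` has not yet been measured; it differs from compound 1 by 3-methoxyphenyl in place of 4-methoxyphenyl on an amide-type nitrogen in a ring. Among the compounds with values here, no step between measured compounds is available to gauge such a move. Because compound 1 sits at the limit of > 40000 nM in this assay, at which 2 of the 3 values shown sit, compound 4 is expected to stay at that limit, with a step of a number no higher from compound 1 to compound 4 (the limit leaves the size open) meaning no change beyond the scatter. The estimate for compound 4 is 40000 nM, spanning 8000 nM to 200000 nM.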

Compound 4, half-maximal inhibitory concentration: > 40000 nM
Compound 4 gave a limit, no number; the forecaster's own chance of this, stated with the estimate: 80%; the middle value lies on the limit itself.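

In this assay, within the data shown here, compound 1 and compound 4 both give only a limit, not a number, and no step between them can be read. As far as these compounds go, what 3-methoxyphenyl in place of 4-methoxyphenyl does to a compound with a readable value stays open.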